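The compounds below may be only part of what the source reports. "The series", "measured", "known", "first", "only" and "open" are said of these compounds alone.

Measured compounds:
Compound 1 `CCCc1nc(CC)c(C(=O)OCCCOCc2ccccc2)n1Cc1ccc(-c2ccccc2S(=O)(=O)NC(=O)OCCC(C)C)cc1F` gives 2 nM in an assay on isolated protein for binding affinity to Type-2 angiotensin II receptor (Homo sapiens); a higher number here means a weaker inhibitor, a lower number a stronger inhibitor.
Compound 2 `CCCc1nc(CC)c(C(=O)OCc2ccccc2OCCC(C)C)n1Cc1ccc(-c2ccccc2S(=O)(=O)NC(=O)OCCC(C)C)cc1F` gives 10 nM in this assay.

Within the data shown here, of the two measured compounds, compound 2 stands with the higher number in this assay; its nearest neighbour is compound 1, and the step of a 5.0-fold higher number from compound 1 to compound 2 (0.70 log units; beyond the scatter) is the only measured step in the set. That step exchanged the whole group on the saturated chain carbon bound to the oxygen next to the carbonyl, so it describes a different site from the one now in question and bears on it only loosely.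

Compound 3 `CCCc1nc(CC)c(C(=O)OCc2ccccc2Sc2ccccc2)n1Cc1ccc(-c2ccccc2S(=O)(=O)NC(=O)OCCC(C)C)cc1F` differs from compound 2 in one place: phenylsulfanyl in place of isopentyloxy on an aromatic carbon. Among the measured compounds shown here, no measured pair shows this exchange, and no pair shows the outcome of any change made at that aromatic carbon. With the shared core and the sulfonyl carbamate side untouched, the account therefore expects compound 3 to stay close to compound 2, with no step beyond the scatter: the expected step is a 1.2-fold higher number from compound 2 to compound 3 (0.08 log units; within the scatter). On that basis compound 3 is estimated at 12 nM, within a range of 4 nM to 40 nM.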

Compound 3, half-maximal inhibitory concentration: 2 nM
For compound 3 the middle estimate is 6.0-fold (0.78 log units) above the measured one; the whole stated range lies above it.
By their numbers in this assay, from the lowest: compounds 1 and 3 (each within the scatter of the next); then compound 2.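

In this assay, among these compounds, the step of a 5.0-fold lower number from compound 2 to compound 3 (0.70 log units; beyond the scatter) is the first measured outcome at this aromatic carbon, and it shows that the position is not indifferent to what it carries: the number moves beyond the scatter, towards a stronger inhibitor. The exchange replaces isopentyloxy, with 6 heavy atoms and no ring, by phenylsulfanyl, with 7 heavy atoms and one six-membered aromatic ring of carbon only, while the hydrogen-bond donor and acceptor counts and the net charge stay the same on both sides. Nothing at hand explains the lower number.

The exchange alters the atom bound to the aromatic carbon and the group beyond it together, so the compounds shown do not separate the sulfur from the ring; phenoxy, which keeps the ring on an oxygen, and isopentylsulfanyl, which keeps the chain on a sulfur, would each change only one of the two. On these data alone, how this aromatic carbon responds to a quite different group, such as an amine or a carboxylic acid, also remains open.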